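Benzylthio replaces ester-bearing chain on benzimidazole acetic acid

A few compounds are considered here, and "the series" means these few. Any claim that something is new, unique, unknown or untested is made for them only; others in the source may bear on it.

Measured compounds:
- compound 1, `CCCCCCSc1nc2ccccc2n1CC(=O)O`, which in an assay on HEK293 cells for displacement of a labelled ligand from prostaglandin D2 receptor 2 (Homo sapiens) (a higher number here means a weaker inhibitor, a lower number a stronger inhibitor), gives 1360 nM
- compound 2, `CCOC(=O)CCSc1nc2ccccc2n1CC(=O)O`, which in this assay gives 11400 nM
- compound 3, `CCOC(=O)CCCSc1nc2ccccc2n1CC(=O)O`, which in this assay gives 4410 nM

Compound 3 stands second highest among the three numbers, a modest distance on either side: a 2.6-fold lower number from compound 2 to compound 3 (0.41 log units; beyond the scatter), while a 3.2-fold higher number from compound 1 to compound 3 (0.51 log units; beyond the scatter). The unmeasured compound 4, `O=C(O)Cn1c(SCc2cccc(Cl)c2)nc2ccccc21`, differs from compound 3 in one place: 3-chlorophenyl in place of 2-(ethoxycarbonyl)ethyl on a saturated chain carbon bound to a sulfur.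

Within the data shown here, no measured pair makes this exact exchange, but two steps bear on it. Both show that an ethoxycarbonyl group on the chain beyond the sulfur raises the number relative to a plain alkyl group: an 8.4-fold higher number from compound 1 to compound 2 (0.92 log units; beyond the scatter) and a 3.2-fold higher number from compound 1 to compound 3 (0.51 log units; beyond the scatter). Compound 4 removes the ester entirely and carries a 3-chlorophenyl on the saturated chain carbon bound to the sulfur, so the direction of compound 1 is the better guide. The writer therefore expects a lower number for compound 4 than for compound 3, with a step of roughly a 5.5-fold lower number from compound 3 to compound 4 (0.74 log units; beyond the scatter), somewhat beyond the scatter. For compound 4 in this assay the estimate is 800 nM, with a range from 200 nM to 3500 nM.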

Compound 4, half-maximal inhibitory concentration: 186 nM
Beside the measured number, compound 4's estimate is 4.3-fold (0.63 log units) above it, and the stated range ends above it.
By their numbers in this assay, from the lowest: compound 4; then compound 1; then compound 3; then compound 2.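

In this assay the 3-chlorophenyl group on the saturated chain carbon bound to a sulfur gives the lowest number of the set, with a 24-fold lower number from compound 3 to compound 4 (1.37 log units; beyond the scatter) and a 61-fold lower number from compound 2 to compound 4 (1.79 log units; beyond the scatter) when it replaces the two ester-bearing chains. The earlier compounds had shown only that these ester-bearing chains stand above the plain alkyl chain, so losing the ester might at best have been expected to recover the alkyl level; instead, with a 7.3-fold lower number from compound 1 to compound 4 (0.86 log units; beyond the scatter) against pentyl on that same carbon, the aromatic ring of carbon carrying chlorine goes clearly past it, and this place in the molecule is shown to accept a ring as well as a chain. Among these compounds, nothing at hand explains why this exchange lowers the number so far.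

The compounds shown leave open whether the ring alone or its chlorine accounts for the step, since a plain phenyl, a 2-chlorophenyl and a 4-chlorophenyl do not appear among them. Also open, on these data alone, is how a longer chain between the sulfur and the ring, or a methoxy group in place of the chlorine, would stand in this assay against these numbers.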